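This account rests on a few compounds, and the source may have more. Where it says the series, first, only, none or still open, it means among the compounds named here.

Compound 1 `COc1ccc(Br)cc1C(=O)Nc1ccccc1` and compound 2 `O=C(Nc1ccc(Sc2nc3ccccc3s2)c(Cl)c1)c1cccc(Br)c1` were both tested in an assay on isolated protein for inhibition of thiosulfate sulfurtransferase (Homo sapiens), with a stated time of 60 min, in the absence of a further agent; a higher number here means a weaker inhibitor, a lower number a stronger inhibitor. For compound 1 the read-out is a limit of the assay, > 100000 nM. For compound 2 the read-out is likewise a limit, > 100000 nM. Compound 2 therefore stands at the limit of > 100000 nM in this assay, at which 2 of the 2 values shown sit, and no number places it in order against its companion. Compound 3 `O=C(Nc1ccc(Sc2nc3ccccc3s2)c(Cl)c1)c1cc(Br)ccc1O` is not yet measured; it differs from compound 2 by hydroxy in place of hydrogen on an aromatic carbon. Among the measured compounds shown here, no step between measured compounds is known here. A modest gain in potency is expected, an at least 3.3-fold lower number from compound 2 to compound 3 (0.52 log units; beyond the scatter). Compound 3 is expected to give roughly 30000 nM, with a range from 5000 nM to 150000 nM, and a real chance that only a limit is reported again.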

Compound 3, half-maximal inhibitory concentration: > 100000 nM
Compound 3 gave a limit, no number; the forecaster's own chance of this, stated with the estimate: 50%; middle value at least 3.3-fold (0.52 log units) away from the limit.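

Among the compounds shown here, compound 2 and compound 3 both give only a limit in this assay and so no step between them can be read: the limit of > 100000 nM in this assay, at which 3 of the 3 values shown sit. The compounds shown leave open whether hydroxy in place of hydrogen changes inhibition at all.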